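Notes on the aryl swap from compound 3 to compound 4

This account rests on a few compounds, and the source may have more. Where it says the series, first, only, none or still open, it means among the compounds named here.

Measured so far:
Compound 1, `COc1ccc(CNC(=O)/C(C#N)=C/c2ccc[nH]2)cc1`: > 50000 nM
Compound 2, `N#C/C(=C\c1ccc[nH]1)C(=O)NCc1ccc(Cl)c(Cl)c1`: > 50000 nM
Compound 3, `N#C/C(=C\c1ccco1)C(=O)NCc1ccc(Cl)c(Cl)c1`: > 50000 nM

In a functional assay on A-431 cells (Homo sapiens) for inhibition, read by MTT assay, with a stated time of 72 h (on this read-out higher numbers stand for weaker inhibition of growth and lower numbers for stronger inhibition of growth), compound 3 gives only the limit > 50000 nM, a limit of the assay and not a number. For compound 2 the value > 50000 nM is likewise a limit. For compound 1 the value > 50000 nM is a limit as well. Among the compounds with values here, this is summed up by the limit of > 50000 nM in this assay, at which 3 of the 3 values shown sit; nothing measured so far has produced a number in this assay.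

Within the data shown here, the one step between neighbouring measured compounds, a step that the two limits leave unreadable from compound 2 to compound 3, is left unreadable by the two limits, so it gives no size and no direction.

Compound 4, `N#C/C(=C\c1ccccc1)C(=O)NCc1ccc(Cl)c(Cl)c1`, differs from compound 3 by phenyl in place of furan-2-yl on a double-bonded chain carbon bound to a double-bonded chain carbon. Among the measured compounds shown here, no measured step bears on this change, and the only measured step is unreadable, so there is no ground to expect a move away from the limit. Compound 4 is therefore expected near the limit, with an estimated value of 50000 nM, ranging from 15000 nM to 150000 nM. The expected step of a number no higher from compound 3 to compound 4 (the limit leaves the size open) is set at essentially none.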

Compound 4, concentration for 50% growth inhibition: 43000 nM
For compound 4 the middle estimate is 1.2-fold (0.07 log units) above the measured one; measured number inside the range.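

In this assay compound 4 is the only compound shown that gives a number rather than a limit, so phenyl on a double-bonded chain carbon bound to a double-bonded chain carbon is the one group here that yields a readable value. The change from furan-2-yl reads as an at least 1.1-fold lower number from compound 3 to compound 4 (0.06 log units; that floor lies within the scatter), and the change from 1H-pyrrol-2-yl reads as an at least 1.1-fold lower number from compound 2 to compound 4 (0.06 log units; that floor lies within the scatter); each is only a floor, so neither fixes the true size of the change. The remaining values are limits of the assay and not numbers: the limit of > 50000 nM in this assay, at which 3 of the 4 values shown sit.

The compounds shown leave open how far the true step runs, since both steps start from a limit. They also leave open whether an amine or a carboxylic acid on the phenyl would move the number in either direction.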